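This account rests on a few compounds, and the source may have more. Where it says the series, first, only, none or still open, it means among the compounds named here.

In an assay on isolated protein for inhibition of DNA topoisomerase 1 (Homo sapiens), with a stated time of 30 min, tested at 100 uM (a higher number here means a stronger effect of the compound at the concentration tested, a lower number a weaker effect), three compounds have been measured so far:
compound 1 `Cc1ccc2nc(-c3ccccc3C(F)(F)F)[nH]c(=O)c2c1` gives 72%;
compound 2 `Cc1ccc2nc(-c3ccccc3OC(F)(F)F)[nH]c(=O)c2c1` gives 66.9%;
compound 3 `Cc1ccc2nc(-c3ccccc3C)[nH]c(=O)c2c1` gives 0%.

Compound 1 shows the largest number of the three, though compound 2 differs from it only by a number 5.1 percentage points lower from compound 1 to compound 2 (within the scatter), so the two cannot be told apart; compound 3 is clearly lower, by a number 72 percentage points lower from compound 1 to compound 3 (beyond the scatter). Compound 4 `CCN(CC)c1ccc2nc(-c3ccccc3C(F)(F)F)[nH]c(=O)c2c1` differs from compound 1 in one place: diethylamino in place of methyl on an aromatic carbon. For the measured compounds named here, every measured step swaps a trifluoromethyl, trifluoromethoxy or methyl group at a place other than the one changed here, so no measured step bears on this change. Without such precedent, compound 4 is expected to stay close to compound 1, with no step beyond the scatter, though the uncertainty is wide. Compound 4 is therefore estimated at 65%, between 30% and 90%, which is expected to mean a number 7 percentage points lower from compound 1 to compound 4 (within the scatter).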

Compound 4, a percentage reported as inhibition, at one concentration (the size of the read-out at that concentration, not a potency): 81.7%
The estimate for compound 4 lay 16.7 percentage points below the measured number; the range from low to high includes it.
By their numbers in this assay, from the lowest: compound 3; then compounds 2, 1 and 4 (each within the scatter of the next, the first and the last beyond it).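

In this assay, diethylamino in place of methyl gives a number 9.7 percentage points higher from compound 1 to compound 4 (within the scatter), so the two numbers cannot be told apart. This aromatic carbon of the shared core therefore carries a group of five heavy atoms, rather than one, without loss of the read-out, at least in this pair. Nothing measured here explains this result.

From the compounds shown here alone, whether a primary amine or a carboxylic acid at this position would do the same remains open. So does whether diethylamino would behave alike with methyl in place of the trifluoromethyl group, the change that took compound 3 to its low number.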